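The compounds below may be only part of what the source reports. "The series", "measured", "known", "first", "only" and "open" are said of these compounds alone.

In a functional assay on MCF7 cells (Homo sapiens) for antiproliferative activity, read by MTT assay, with a stated time of 48 h (a lower number here means a stronger inhibitor, a higher number a weaker inhibitor), three close relatives of compound 4 have already been examined, and none of them produced a number. Compound 1 `Cc1cnc(Nc2ccc(S(N)(=O)=O)cc2)nc1Nc1nc2ccccc2s1` reaches only the limit of the assay, > 50000 nM. Compound 2 `Cc1cnc(Nc2ccc(Cl)cc2)nc1Nc1nc2ccccc2s1` likewise stops at a limit, > 50000 nM. Compound 3 `Cc1cnc(Nc2cccc(F)c2)nc1Nc1nc2ccccc2s1` again returns a limit, > 50000 nM. The step that the two limits leave unreadable from compound 1 to compound 2 therefore cannot be read, and neither can a step that the two limits leave unreadable from compound 2 to compound 3, because of the limit of > 50000 nM in this assay, at which 3 of the 3 values shown sit. Compound 2 thus stands at the limit of this assay, with nothing to set it apart from compound 1 or compound 3.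

Compound 4 `Cc1cnc(Nc2ccc(N3CCCCC3)cc2)nc1Nc1nc2ccccc2s1` differs from compound 2 in a single place: piperidin-1-yl in place of chloro on an aromatic carbon. The piperidin-1-yl enters on an aromatic carbon of the six-membered aromatic ring of carbon only, para to a large group, where the chloro of compound 2 stood.

Neither measured step bears a readable size on this change, so no direction can be taken from them; the three limits only show that this compound series has so far stayed outside the measurable window of this assay. Compound 4 is therefore expected near 40000 nM, within 8000 nM to 60000 nM, most likely again as a limit. That estimate means an expected step of an at least 1.2-fold lower number from compound 2 to compound 4 (0.09 log units; that floor lies within the scatter).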

Compound 4, half-maximal inhibitory concentration: > 50000 nM
Compound 4: only a limit was reported; the forecaster's own chance of this, stated with the estimate: 65%; middle value at least 1.2-fold (0.09 log units) from the limit.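

In this assay compound 4 returns > 50000 nM, which is a limit and not a number. The steps to compound 4 from compound 1 and compound 2 therefore cannot be read: the limit of > 50000 nM in this assay, at which 4 of the 4 values shown sit. The compounds shown leave open how far each lies from that limit, and whether any change on the shared core would give a measurable value.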